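A few compounds are considered here, and "the series" means these few. Any claim that something is new, unique, unknown or untested is made for them only; others in the source may bear on it.

In a functional assay on HEK293 cells for agonist activity at Thyrotropin receptor (Homo sapiens), read by cAMP accumulation (on this read-out higher numbers stand for larger maximal responses and lower numbers for smaller maximal responses), two compounds of a shared core have been measured. Compound 1 `COc1cccc(-c2nc(SC)nc3sc(C(=O)NCC#N)c(N)c23)c1` gives 3.6% in this assay. Compound 2 `COc1cccc(-c2nc(SC)nc3sc(C(=O)NC(C)(C)C)c(N)c23)c1OC` gives 3% in this assay. The two numbers lie within the usual scatter of each other, so neither compound can be told apart from the other on this read-out, and both sit near the bottom of the scale, far from a full response.

Compound 3 `COc1cccc(-c2nc(SC)nc3sc(C(=O)NCc4ccccc4)c(N)c23)c1` has not yet been measured in this assay. It differs from compound 1 in one place: phenyl in place of cyano on a saturated chain carbon bound to an amide-type nitrogen. The rest of the molecule, including the shared core, is unchanged.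

For the measured compounds named here, no measured pair shows what a change at this position does to the maximal response. Both measured compounds give very small responses, and nothing in the data points toward a larger one. The step from compound 1 to compound 3 is therefore expected to be a number 1.4 percentage points higher from compound 1 to compound 3 (within the scatter), that is, none beyond the scatter. For compound 3 in this assay a value of 5% is estimated, with a range from 0% to 20%.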

Compound 3, largest response reached (reported as efficacy), in percent of the reference or control that the assay uses: 3%
For compound 3 the middle estimate is 2 percentage points above the measured one; the measured number falls inside the stated range.
By their numbers in this assay, from the lowest: compounds 2, 3 and 1 (each within the scatter of the next).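

In this assay, for the compounds shown here, phenyl in place of cyano on a saturated chain carbon bound to an amide-type nitrogen gives the first step that can be read at this position, a number 0.6 percentage points lower from compound 1 to compound 3 (within the scatter), so the (cyanomethyl)carbamoyl and benzylcarbamoyl compounds cannot be told apart on this read-out. The change is not a small one on paper: two heavy atoms with a triple bond and a hydrogen-bond acceptor leave, and a six-membered aromatic ring of six carbons enters, yet the maximal response stays near the bottom of the scale. No measurement at hand accounts for this result.

On these data alone, whether an amine or a carboxylic acid on this chain, or a longer chain carrying the phenyl ring, would lift the response clear of the bottom of the scale remains open. The other parts of the molecule also remain open, since no single change outside this chain can yet be read, and so the compounds shown do not reveal which part of the structure, if any, controls the size of the response.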